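Carboxy for nitro on the benzimidazole of compound 1

A few compounds are considered here, and "the series" means these few. Any claim that something is new, unique, unknown or untested is made for them only; others in the source may bear on it.

Compound 1 `Cc1nn(-c2ccccc2)c(Oc2ccc(-c3nc4cc([N+](=O)[O-])ccc4[nH]3)cc2)c1/C=N/Nc1ccccc1` gives 50 nM in a functional assay on MCF7 cells (Homo sapiens) for cytotoxicity, read by sulforhodamine B assay, with a stated time of 48 h, in the presence of a further agent that is not named here; on this read-out higher numbers stand for weaker inhibition of growth and lower numbers for stronger inhibition of growth. Compound 2 `Cc1nn(-c2ccccc2)c(Oc2ccc(-c3nc4cc([N+](=O)[O-])ccc4[nH]3)cc2)c1/C=N/NC(N)=O` gives 50 nM in this assay, and the step of no change at the digits printed from compound 1 to compound 2 (within the scatter) leaves compound 1 level with compound 2. Compound 3 `Cc1nn(-c2ccccc2)c(Oc2ccc(-c3nc4cc([N+](=O)[O-])ccc4[nH]3)cc2)c1/C=N/NC(N)=S` returns only a limit of the assay in this assay, > 100000 nM. The steps of an at least 2000-fold higher number from compound 1 to compound 3 (3.30 log units; beyond the scatter) and an at least 2000-fold higher number from compound 2 to compound 3 (3.30 log units; beyond the scatter) are large, and both sit on the amine nitrogen of the hydrazone end of the shared core.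

Compound 4 `Cc1nn(-c2ccccc2)c(Oc2ccc(-c3nc4cc(C(=O)O)ccc4[nH]3)cc2)c1/C=N/Nc1ccccc1` differs from compound 1 at a different place: carboxy in place of nitro on an aromatic carbon. Within the data shown here, none of the three measured steps touches the 5-nitro-1H-benzimidazol-2-yl part, so no measured step bears directly on this change, and the expectation rests only on the fact that the rest of the structure is unchanged. Compound 4 is expected to give about 150 nM, within a wide range from 30 nM to 3000 nM. The step of a 3.0-fold higher number from compound 1 to compound 4 (0.48 log units; beyond the scatter) is thus expected to be modest, toward weaker inhibition of growth, with the uncertainty reaching in both directions.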

Compound 4, concentration for 50% growth inhibition: 90 nM
Compound 4: the middle estimate sits 1.7-fold (0.22 log units) above what was measured; measured number inside the range.
By their numbers in this assay, from the lowest: compounds 1, 2 and 4 (each within the scatter of the next). At a limit, above all of these: compound 3.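

Carboxy in place of nitro on an aromatic carbon gives a 1.8-fold higher number from compound 1 to compound 4 (0.26 log units; within the scatter) in this assay, so the first change at this position, which the earlier compounds left untouched, produces no shift beyond the scatter. The level of compound 1 in this assay therefore does not depend on the nitro group specifically, at least with a phenyl group on the amine nitrogen of the hydrazone end. Nothing measured here bears on why these two groups give values within the scatter of each other.

Going by these compounds, whether an amine, a methyl ester or a primary amide at this position would hold the same level remains open. So does whether carboxy would behave the same way with the carbamoyl end of compound 2 in place of the phenyl end.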